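The compounds below may be only part of what the source reports. "The series", "measured", "known", "first", "only" and "open" are said of these compounds alone.

Measured so far:
compound 1 `Nc1ccc(-c2nc3cc(F)ccc3s2)cc1I` — 10200 nM
compound 2 `Nc1ccc(-c2nc3cc(F)ccc3s2)cc1` — < 10 nM
compound 3 `Cc1cc(-c2nc3ccccc3s2)ccc1N` — 18600 nM

In a functional assay on NCI-H226 cells (Homo sapiens) for inhibition (a higher number here means a weaker inhibitor of growth, a lower number a stronger inhibitor of growth), compound 2 gives < 10 nM, which is a limit of the assay and not a number; it sits at the limit of < 10 nM in this assay, at which 1 of the 3 values shown sits. Compound 1 gives 10200 nM in this assay. Among the compounds with values here, compound 3 gives 18600 nM in this assay; compound 3 carries a methyl group and lacks the fluoro of compound 2, so no single step links it to compound 2 and only its value stands on its own.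

Compound 4 `Nc1ccc(-c2nc3cc(F)ccc3s2)cc1Cl` follows from compound 2 by chloro in place of hydrogen on an aromatic carbon. Within the data shown here, the one measured step that bears on this change is an at least 1000-fold lower number from compound 1 to compound 2 (3.00 log units; beyond the scatter), where a halogen at the same place was removed. Read in reverse, putting a halogen back at that place gave a large rise in the number; compound 4 carries chloro rather than iodo there, and no measured pair shows how a chloro at that place behaves. A rise beyond the scatter is therefore expected, though probably not as large as the iodo step. Compound 4 is estimated at 800 nM, range 50 nM to 8000 nM, which means an expected step of an at least 80-fold higher number from compound 2 to compound 4 (1.90 log units; beyond the scatter).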

Compound 4, concentration for 50% growth inhibition: 30 nM
The estimate for compound 4 lay 27-fold (1.43 log units) above the measured number; measured number below the stated range.
By their numbers in this assay, from the lowest: compound 4; then compounds 1 and 3 (each within the scatter of the next). At a limit, below all of these: compound 2.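

At the aromatic carbon ortho to an amino group, the outcome in this assay depends on which halogen sits there: chloro in place of iodo gives a 340-fold lower number from compound 1 to compound 4 (2.53 log units; beyond the scatter), so the high number of compound 1 does not carry over to every halogen at this place. Chloro in place of hydrogen still gives an at least 3.0-fold higher number from compound 2 to compound 4 (0.47 log units; beyond the scatter), so the chloro is not fully neutral here. Compound 2 stands at a limit and not at a number, which leaves that step without a fixed size: the limit of < 10 nM in this assay, at which 1 of the 4 values shown sits.

Open, from the compounds shown here alone, is whether bromo or methoxy at this place would give a number closer to that of compound 4 or that of compound 1. Compound 3 gives 18600 nM with a methyl group, but it also lacks the fluoro, so the effect of methyl alone at this place stays unresolved.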